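Acetyl capping of a hydroxy group on compound 1

This account rests on a few compounds, and the source may have more. Where it says the series, first, only, none or still open, it means among the compounds named here.

Compound 1 `C/C=C(\C)C(=O)O[C@H]1[C@]2(C)C[C@@H]3O[C@@]1(O)C=C1C4=CC(=O)O[C@@H](c5ccoc5)[C@]4(C)CC[C@@H]1[C@]3(C)[C@@H]2[C@@H](O)C(=O)OC` belongs to a small set of close relatives built on one shared core. In a functional assay on HeLa cells (Homo sapiens) for inhibition, read by MTT assay, with a stated time of 24 h (a lower number here means a stronger inhibitor, a higher number a weaker inhibitor), compound 1 gives > 100000 nM, which is a limit of the assay and not a measured number. Compound 2 `COC(=O)[C@H](O)[C@@H]1[C@@]2(C)C[C@@H]3O[C@@](O)(C=C4C5=CC(=O)O[C@@H](c6ccoc6)[C@]5(C)CC[C@@H]4[C@@]31C)[C@H]2O` gives > 100000 nM in this assay, again only a limit. Compound 3 `C/C=C(\C)C(=O)O[C@@H]1[C@]2(OC(=O)CC)C=C3C4=CC(=O)O[C@@H](c5ccoc5)[C@]4(C)CC[C@@H]3[C@@]3(C)[C@H](C[C@]1(C)[C@H]3[C@@H](O)C(=O)OC)O2` gives > 100000 nM, once more a limit. The steps from compound 1 to its neighbours are therefore unreadable: a step that the two limits leave unreadable from compound 1 to compound 2 and a step that the two limits leave unreadable from compound 1 to compound 3, because of the limit of > 100000 nM in this assay, at which 3 of the 3 values shown sit.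

Compound 4 `C/C=C(\C)C(=O)O[C@H]1[C@]2(C)C[C@@H]3O[C@@]1(O)C=C1C4=CC(=O)O[C@@H](c5ccoc5)[C@]4(C)CC[C@@H]1[C@]3(C)[C@@H]2[C@@H](OC(C)=O)C(=O)OC` differs from compound 1 in one place: acetyl in place of hydrogen on an oxygen on a saturated carbon. Cut one bond further out, the change reads hydroxy to acetoxy. Nothing measured bears on this change, since every step from compound 1 sits at the limit; no direction and no size can be read from them. The expectation is that compound 4 also reaches only the limit, so the expected step is a step that the limit leaves unreadable from compound 1 to compound 4. Compound 4 is accordingly estimated at 150000 nM in this assay, within a range from 50000 nM to 500000 nM.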

Compound 4, half-maximal inhibitory concentration: > 100000 nM
Compound 4 was reported as a limit (the forecaster's own chance of this, stated with the estimate: 85%); the middle value does not contradict the limit.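

No new step can be read, because compound 1 and compound 4 both stop at a limit rather than a measured number: the limit of > 100000 nM in this assay, at which 4 of the 4 values shown sit.

The compounds shown leave open how strongly any of them acts in this assay, and whether changing hydroxy to acetoxy shifts that at all.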